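The source may report more compounds than this note shows. Statements on the series, on what has been measured and on what is new or still open speak of the compounds shown alone.

In an in vitro assay on 293-EBNA cells for binding affinity to corticotropin-releasing factor receptor 1 (Homo sapiens) (a lower number here means a stronger inhibitor, a higher number a weaker inhibitor), the measured compounds stand as follows:

compound 1 `Cc1nc(N2CCCC2)c2nnn(-c3ccc(C(C)C)cc3Br)c2n1`: 194 nM
compound 2 `COCCNc1nc(C)nc2c1nnn2-c1ccc(C(C)C)cc1Br`: 242 nM

Compound 2 holds the highest of the two numbers; its nearest neighbour is compound 1, and the step of a 1.2-fold higher number from compound 1 to compound 2 (0.10 log units; within the scatter) lies within the scatter, so the two are not separable on these data. Going by the values given here, the only change measured so far is that one, (2-methoxyethyl)amino in place of pyrrolidin-1-yl on an aromatic carbon, and it moved nothing beyond the noise.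

Compound 3 `CCC(CC)Oc1nc(C)nc2c1nnn2-c1ccc(C(C)C)cc1Br` is the next member. Relative to compound 2 the difference is (pentan-3-yl)oxy in place of (2-methoxyethyl)amino on an aromatic carbon, at the same aromatic carbon of the shared core. Among the compounds with values here, no measured step covers a swap of an amino group for an ether at this carbon; the one step that does bear on the site, a 1.2-fold higher number from compound 1 to compound 2 (0.10 log units; within the scatter), shows it tolerating a different substituent without a shift beyond the scatter. On that basis the expected step of a 1.0-fold higher number from compound 2 to compound 3 (0.01 log units; within the scatter) is none beyond the scatter, with a wide range to cover the untested ether. Compound 3 is estimated at 250 nM, between 80 nM and 800 nM.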

Compound 3, inhibition constant: 1.9 nM
Compound 3: middle estimate off by 130-fold (2.12 log units), on the high side; the whole stated range lies above it.
By their numbers in this assay, from the lowest: compound 3; then compounds 1 and 2 (each within the scatter of the next).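

In this assay this aromatic carbon proves far from indifferent: (pentan-3-yl)oxy in place of (2-methoxyethyl)amino gives a 130-fold lower number from compound 2 to compound 3 (2.11 log units; beyond the scatter) on the shared core, and (pentan-3-yl)oxy in place of pyrrolidin-1-yl gives a 100-fold lower number from compound 1 to compound 3 (2.01 log units; beyond the scatter) on the same core. Going by these compounds alone, the earlier pair showed only that two nitrogen-linked groups could not be told apart here; the ether shows that the site can respond strongly, and the large shift appears from both starting points. No measurement shown accounts for the size of this shift.

The change replaces the linking atom and the carbon chain together, so the compounds shown leave open whether the gain follows the oxygen link, the branched pentan-3-yl group, or only the two combined. A pentan-3-ylamino group at this carbon would test the chain with a nitrogen link and a 2-methoxyethoxy group would test the oxygen link with the chain of compound 2, while a smaller ether such as methoxy would show how much of the branched chain is needed.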